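Moving a methyl around the phenyl ring of compound 3

The compounds below may be only part of what the source reports. "The series", "measured", "known", "first", "only" and "open" are said of these compounds alone.

Compound 1 `C[C@H](O)[C@@H](CCc1cccc(C(N)=O)c1)n1cnc2c(N)ncnc21`: in an assay on isolated protein for inhibition of adenosine deaminase (Bos taurus), with a stated time of 5 min (on this read-out lower numbers stand for stronger inhibition and higher numbers for weaker inhibition), compound 1 gives 2.9 nM.
Compound 2 `C[C@H](O)[C@@H](CSc1ccccc1)n1cnc2c(N)ncnc21`: in this assay compound 2 gives 135 nM.
Compound 3 `Cc1ccccc1SC[C@H]([C@H](C)O)n1cnc2c(N)ncnc21`: in this assay compound 3 gives 66 nM.

Among these three numbers compound 3 stands second highest: it is closest to compound 2 and furthest from compound 1, which gives a much lower number. Going by the values given here, the one measured step that touches the phenyl ring, a 2.0-fold lower number from compound 2 to compound 3 (0.31 log units; beyond the scatter), put a methyl onto an aromatic carbon and gave a modest gain.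

Compound 4 `Cc1cccc(SC[C@H]([C@H](C)O)n2cnc3c(N)ncnc32)c1` keeps every atom of compound 3 but joins them differently: 3-methylphenyl in place of 2-methylphenyl on a sulfur. Among the compounds with values here, no measured pair shows what moving the methyl from one ring carbon to another does, so the only guide is that compound 2 and compound 3 sit close together whether the methyl is present or absent. A step of similar modest size in either direction, or none beyond the scatter, is therefore expected: a 1.3-fold higher number from compound 3 to compound 4 (0.11 log units; within the scatter). Compound 4 is estimated at 85 nM in this assay, within 30 nM to 220 nM.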

Compound 4, inhibition constant: 49 nM
Estimate against measurement, compound 4: 1.7-fold (0.24 log units) above, within the range that was stated.
By their numbers in this assay, from the lowest: compound 1; then compounds 4 and 3 (each within the scatter of the next); then compound 2.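

Moving the methyl on the ring in this assay gives a 1.3-fold lower number from compound 3 to compound 4 (0.13 log units; within the scatter) and so does not separate 2-methylphenyl from 3-methylphenyl on the sulfur. Compared with the unsubstituted phenyl, the newly measured isomer gives a 2.8-fold lower number from compound 2 to compound 4 (0.44 log units; beyond the scatter) and so joins the earlier methyl step in showing a modest gain, which means this gain is now seen with the methyl on either of two different ring carbons. Nothing available here gives a reason for this result.

The compounds shown leave open whether a group other than methyl, such as a chlorine atom, a methoxy group or an amine, would behave the same way on this phenyl ring. They also leave open what would follow if an oxygen atom took the place of the sulfur.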